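Para halogen swap carried to a second series

The compounds below may be only part of what the source reports. "The series", "measured", "known", "first", "only" and "open" are said of these compounds alone.

Measured in a functional assay on K562 cells (Homo sapiens) for cytotoxicity, read by MTT assay, with a stated time of 24 h; a higher number here means a weaker inhibitor, a lower number a stronger inhibitor:
Compound 1 `COc1cc(/C=C2\CN(C)C/C(=C\c3ccc(F)cc3)C2=O)cc(OC)c1`: 11300 nM
Compound 2 `COc1cc(/C=C2\CN(C)C/C(=C\c3ccc(Cl)cc3)C2=O)cc(OC)c1`: 13300 nM
Compound 3 `CN1C/C(=C\c2ccc(F)cc2)C(=O)/C(=C/c2ccc(C#N)cc2)C1`: 11300 nM

Among the compounds with values here, the one change that repeats is chloro in place of fluoro on an aromatic carbon; it gave a 1.2-fold higher number from compound 1 to compound 2 (0.07 log units; within the scatter). Compound 3 stands level with compound 1 at the digits given, and the difference between the core of compound 3 and the core of compound 1 is not broken down here. Compound 4 `CN1C/C(=C\c2ccc(Cl)cc2)C(=O)/C(=C/c2ccc(C#N)cc2)C1` carries the same change, (chloro in place of fluoro on an aromatic carbon), made on the core of compound 3. From compound 3 to compound 4 a step of about a 1.2-fold higher number from compound 3 to compound 4 (0.06 log units; within the scatter) is expected, resting on a 1.2-fold higher number from compound 1 to compound 2 (0.07 log units; within the scatter), which stayed within the scatter. Compound 4 is therefore estimated at 13000 nM, with the range 7000 nM to 25000 nM.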

Compound 4, half-maximal inhibitory concentration: 13300 nM
Estimate against measurement, compound 4: 1.0-fold (0.01 log units) below, and the stated range covers the measured number.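

In this assay, chloro in place of fluoro on the core of compound 3 gave a 1.2-fold higher number from compound 3 to compound 4 (0.07 log units; within the scatter), and this step matches the earlier one on the other core: the same change on two cores in this assay, a 1.2-fold higher number (0.07 log units; within the scatter) from compound 1 to compound 2 and a 1.2-fold higher number (0.07 log units; within the scatter) from compound 3 to compound 4, 1.0-fold (0.00 log units) apart, within the scatter of two such steps

Both steps lie within the scatter, so the swap carries across these two cores only in the sense that it leaves no readable difference on either. This does not show a real halogen effect that transfers, and two cores with one pair of halogens give no rule for the wider series.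

Still open, as far as these compounds go, is whether bromo, an amine or a carboxylic acid in place of the halogen on this ring would give a step beyond the scatter.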